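Swapping a nitrooxy arm for a bromoethyl arm

A few compounds are considered here, and "the series" means these few. Any claim that something is new, unique, unknown or untested is made for them only; others in the source may bear on it.

Measured so far:
compound 1, `COc1ccc(C2=NNC(c3ccco3)C2)cc1OC`, 53%
compound 2, `COc1ccc(C2=NN(C(=O)CBr)C(c3ccco3)C2)cc1OC`, 46%
compound 3, `COc1ccc(C2=NN(C(=O)CO[N+](=O)[O-])C(c3ccco3)C2)cc1OC`, 37%

All three compounds share the same core and were tested in a functional assay on the whole organism (strain albino) for inhibition, with Rattus norvegicus as the target, read by paw edema, with stated times of 30 min and 2 h, at a dose of 100 mg/kg by the oral route; a lower number here means less inhibition, a higher number more inhibition at the dose given (going by the name of the read-out). Compound 3 has the lowest of the three numbers. Its nearest neighbour is compound 2, a step of a number 9 percentage points lower from compound 2 to compound 3 (within the scatter), and its furthest is compound 1, a step of a number 16 percentage points lower from compound 1 to compound 3 (beyond the scatter).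

The new compound is compound 4, `COc1ccc(C2=NN(C(=O)C(C)Br)C(c3ccco3)C2)cc1OC`. The change from compound 3 is 1-bromoethyl in place of (nitrooxy)methyl on a carbonyl carbon. Going by the values given here, two measured steps bear on it. The step of a number 9 percentage points lower from compound 2 to compound 3 (within the scatter) is the closest parallel, run backwards: it removed a bromo from the chain and put nitrooxy in its place, and the number moved within the scatter. The step of a number 7 percentage points lower from compound 1 to compound 2 (within the scatter) shows that a bromine-bearing acyl chain on the ring nitrogen also left the number within the scatter of the parent. Taken together, going back to a bromine-bearing chain is expected to give a step of a number 9 percentage points higher from compound 3 to compound 4 (within the scatter), upward but not clearly beyond the scatter. Compound 4 is therefore estimated at 46%, with a range from 33% to 58%.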

Compound 4, a percentage reported as inhibition, in the whole organism at one dose (the size of the read-out at that dose, not a potency): 36%
Estimate against measurement, compound 4: 10 percentage points above, within the range that was stated.
By their numbers in this assay, from the lowest: compounds 4, 3, 2 and 1 (each within the scatter of the next, the first and the last beyond it).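

In this assay, 1-bromoethyl in place of (nitrooxy)methyl on the carbonyl carbon gives a number 1 percentage points lower from compound 3 to compound 4 (within the scatter), so the two arms cannot be told apart at this position, even though they share little beyond their place on the carbonyl. Methyl in place of hydrogen on the bromine-bearing chain carbon gives a number 10 percentage points lower from compound 2 to compound 4 (within the scatter), so this small addition also stays unresolved in this whole-animal test. Measured against the unsubstituted ring nitrogen of compound 1, the new acyl group gives a number 17 percentage points lower from compound 1 to compound 4 (beyond the scatter), which makes compound 4 the second compound, after compound 3, with a step from compound 1 beyond the scatter, whereas compound 2 stays within it.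

The data shown offer nothing that explains these numbers. As far as these compounds go, it remains open whether any group on this acyl chain could lift the number above that of compound 1, for example an amine or a carboxylic acid in place of the bromine, or a longer chain carrying the bromine or the nitrooxy group.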